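Fluorine pattern on the pendant aryl ring of the core

A few compounds are considered here, and "the series" means these few. Any claim that something is new, unique, unknown or untested is made for them only; others in the source may bear on it.

Measured so far in an assay on isolated protein for agonist activity at Free fatty acid receptor 1 (Homo sapiens); on this read-out lower numbers stand for an effect already at smaller amounts and higher numbers for an effect only at larger amounts of compound:
Compound 1 `CC#CC(CC(=O)O)c1ccc(OCc2ccn3cc(-c4ccccc4)nc3c2)cc1`: 1260 nM
Compound 2 `CC#CC(CC(=O)O)c1ccc(OCc2ccn3cc(-c4ccc(C)cc4C)nc3c2)cc1`: 503 nM
Compound 3 `CC#CC(CC(=O)O)c1ccc(OCc2ccn3cc(-c4cc(F)ccc4F)nc3c2)cc1`: 639 nM

Compound 3 sits second highest of the three numbers in this assay, with compound 2 nearest and compound 1 furthest; both of those gaps are within the scatter, so the three measured compounds are not separable on this read-out apart from the step from compound 1 to compound 2, which is a 2.5-fold lower number from compound 1 to compound 2 (0.40 log units; beyond the scatter). The unmeasured compound 4 `CC#CC(CC(=O)O)c1ccc(OCc2ccn3cc(-c4ccc(F)cc4)nc3c2)cc1` differs from compound 3 in one place: 4-fluorophenyl in place of 2,5-difluorophenyl on an aromatic carbon.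

Going by the values given here, two measured steps bear on this change. Adding two fluorines to the plain phenyl gave a 2.0-fold lower number from compound 1 to compound 3 (0.29 log units; within the scatter), and swapping that difluorophenyl for the dimethylphenyl gave a 1.3-fold higher number from compound 2 to compound 3 (0.10 log units; within the scatter). Compound 4 keeps one fluorine and so lies between the plain phenyl of compound 1 and the difluorophenyl of compound 3. With the phenyl-to-difluorophenyl step itself within the scatter, no step beyond the scatter is expected from compound 3 to compound 4; the expected step is a 1.3-fold higher number from compound 3 to compound 4 (0.10 log units; within the scatter). Compound 4 is estimated at 800 nM, within 400 nM to 1600 nM.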

Compound 4, half-maximal effective concentration: 783 nM
The estimate for compound 4 lay 1.0-fold (0.01 log units) above the measured number; measured number inside the range.
By their numbers in this assay, from the lowest: compounds 2, 3, 4 and 1 (each within the scatter of the next, the first and the last beyond it).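

In this assay, a single fluorine on the phenyl at this aromatic carbon of the five-membered ring gives no step beyond the scatter, with a 1.6-fold lower number from compound 1 to compound 4 (0.21 log units; within the scatter), and removing the second fluorine pattern of the 2,5-difluorophenyl gives none either, with a 1.2-fold higher number from compound 3 to compound 4 (0.09 log units; within the scatter). Going by these compounds alone, the 4-fluorophenyl also stays within the scatter of the 2,4-dimethylphenyl, with a 1.6-fold higher number from compound 2 to compound 4 (0.19 log units; within the scatter), so the only step beyond the scatter at this position remains a 2.5-fold lower number from compound 1 to compound 2 (0.40 log units; beyond the scatter). Nothing on hand offers an explanation for these steps.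

On these data alone, it remains open whether a methoxy, an amine or a trifluoromethyl on this phenyl, or a saturated cyclohexyl in its place, would shift the number beyond the scatter. Also open, as far as these compounds go, is whether these small steps would hold with a shorter chain or an amide in place of the carboxylic acid.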